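Triazole substituent change on a flavanone core

The source may hold more compounds than are shown below. What is called first, only, known or untested is meant among the compounds shown, and "the series" means these compounds.

Measured compounds:
compound 1 `COc1ccc([C@@H]2CC(=O)c3c(O)cc(OCc4cn(Cc5ccccc5Cl)nn4)cc3O2)cc1O`: 6140 nM
compound 2 `CCCCn1cc(COc2cc(O)c3c(c2)O[C@H](c2ccc(OC)c(O)c2)C/C3=N\O)nn1`: 8900 nM
compound 3 `COc1ccc([C@@H]2C/C(=N\O)c3c(O)cc(OCc4cn(CC5CC5)nn4)cc3O2)cc1O`: 6320 nM

In a functional assay on RAW264.7 cells (Mus musculus) for inhibition, read by Griess assay, with stated times of 2 h and 24 h (a lower number here means a stronger inhibitor, a higher number a weaker inhibitor), compound 1 gives 6140 nM, the lowest of the three numbers, though its gaps to compound 3 and to compound 2 are both within the scatter, so no order among them can be claimed. Compound 4 `CCn1cc(COc2cc(O)c3c(c2)O[C@H](c2ccc(OC)c(O)c2)CC3=O)nn1` has not yet been measured. It differs from compound 1 by methyl in place of 2-chlorophenyl on a saturated chain carbon bound to an aromatic nitrogen. Within the data shown here, one measured step touches the same place on a related core: a 1.4-fold lower number from compound 2 to compound 3 (0.15 log units; within the scatter). That step, with a change of similar character on the same saturated chain carbon bound to an aromatic nitrogen, stayed within the scatter, which gives no reason to expect a step beyond the scatter in this assay here either. The estimate for compound 4 is therefore 6500 nM, with a range of 3000 nM to 14000 nM, corresponding to an expected step of a 1.1-fold higher number from compound 1 to compound 4 (0.02 log units; within the scatter).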

Compound 4, half-maximal inhibitory concentration: 15000 nM
Compound 4: middle estimate off by 2.3-fold (0.36 log units), on the low side; the measured number lies above the stated range.
By their numbers in this assay, from the lowest: compounds 1, 3, 2 and 4 (each within the scatter of the next, the first and the last beyond it).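

In this assay, the change from 2-chlorobenzyl to ethyl gives a 2.4-fold higher number from compound 1 to compound 4 (0.39 log units; beyond the scatter), so this place can move the number beyond the scatter, though only modestly. The earlier step at the same place, a 1.4-fold lower number from compound 2 to compound 3 (0.15 log units; within the scatter), exchanged one small saturated group for another on a related core, whereas this one removes a six-membered aromatic ring of carbon only along with its chlorine. Nothing available here explains the step.

Among these compounds, the single pair cannot separate the part played by the ring from that of the chlorine, and a plain benzyl group on the core of compound 1 would bear on that question. Going by these compounds, how a longer chain, such as butyl, or a chain ending in an amine or a carboxylic acid would read on that core also stays open.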